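A second fluoro on compound 2

This account rests on a few compounds, and the source may have more. Where it says the series, first, only, none or still open, it means among the compounds named here.

Going by the values given here, in a functional assay on HL-60 cells (Homo sapiens) for cytotoxicity, read by WST assay, with a stated time of 48 h (on this read-out higher numbers stand for an effect only at larger amounts of compound and lower numbers for an effect already at smaller amounts), compound 2 (`Fc1ccc(C[C@H]2COC[C@@H]2Cc2ccc(Cl)c(Cl)c2)cc1`) gives 43000 nM, the highest of the two numbers known, while compound 1 (`Fc1cccc(C[C@H]2COC[C@@H]2Cc2ccc(Cl)c(Cl)c2)c1`) gives 20000 nM. Compound 3 (`Fc1ccc(C[C@H]2COC[C@@H]2Cc2ccc(Cl)c(Cl)c2)cc1F`) has fluoro in place of hydrogen on an aromatic carbon, ortho to a fluoro group (fluoro in place of hydrogen on an aromatic carbon). Among the compounds with values here, only one measured step bears on this, and it is modest: a 2.2-fold higher number from compound 1 to compound 2 (0.33 log units; beyond the scatter). Compound 3 holds both fluoro groups seen singly in compound 1 and compound 2, so a value between theirs is expected in this assay. The expected change is an estimated 1.4-fold lower number from compound 2 to compound 3 (0.16 log units; within the scatter), small and possibly lost in the scatter. For compound 3 the estimated value is 30000 nM, with an expected range of 14000 nM to 65000 nM.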

Compound 3, half-maximal effective concentration: 18000 nM
Estimate against measurement, compound 3: 1.7-fold (0.22 log units) above, within the range that was stated.
By their numbers in this assay, from the lowest: compounds 3 and 1 (each within the scatter of the next); then compound 2.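

Fluoro ortho to a fluoro group is not silent in this assay: it gives a 2.4-fold lower number from compound 2 to compound 3 (0.38 log units; beyond the scatter) and so takes the number back beyond the scatter. Set against the other single fluoro compound, the same kind of change gives a 1.1-fold lower number from compound 1 to compound 3 (0.05 log units; within the scatter) and stays within the scatter, so the difluoro ring reads like the ring of compound 1 and not like that of compound 2. No measurement on hand accounts for this.

From the compounds shown here alone, whether a methoxy group or an amine at this place would give a similar number remains open. So does whether a second fluoro group would act the same way on the core of compound 1.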